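The compounds below may be only part of what the source reports. "The series", "measured", "known", "first", "only" and "open" are said of these compounds alone.

Working notes on the series. The shared core of compound 1 `Cc1cnc(Nc2ccc(S(N)(=O)=O)cc2)nc1Nc1nc2ccccc2s1` carries a sulfamoyl group; in a functional assay on MDA-MB-231 cells (Homo sapiens) for antiproliferative activity, read by MTT assay, with a stated time of 48 h (a lower number here means a stronger inhibitor, a higher number a weaker inhibitor), compound 1 gives 16800 nM. Of the three numbers in hand that is the highest. Compound 2 `NS(=O)(=O)c1ccc(Nc2nccc(Nc3nc4ccccc4s3)n2)cc1` gives 5000 nM in this assay, and the step of a 3.4-fold lower number from compound 1 to compound 2 (0.53 log units; beyond the scatter) is the one clear movement in the set. Compound 3 `Cc1ccc2nc(Nc3nc(Nc4ccc(S(N)(=O)=O)cc4)ncc3C)sc2c1` gives 9080 nM, and the step of a 1.9-fold lower number from compound 1 to compound 3 (0.27 log units; within the scatter) stays within the scatter, so compound 1 and compound 3 cannot be ordered against each other.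

Compound 4 `Cc1cnc(Nc2ccc(S(C)(=O)=O)cc2)nc1Nc1nc2ccccc2s1` differs from compound 1 in one place: methyl in place of amino on a sulfonyl sulfur. Among the measured compounds shown here, both measured steps concern a methyl or a hydrogen on an aromatic carbon of the core; neither touches the sulfonyl sulfur, so no measured step bears on this change, and the expectation rests on the change itself rather than on any step in hand. With a hydrogen-bond donor leaving and nothing entering in its place, a weakening is expected, but only a modest one, and it may not clear the scatter. Compound 4 is therefore estimated at 25000 nM in this assay, with a range from 8000 nM to 80000 nM. That estimate means a step of a 1.5-fold higher number from compound 1 to compound 4 (0.17 log units; within the scatter) that is expected rather than observed.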

Compound 4, half-maximal inhibitory concentration: 14800 nM
Beside the measured number, compound 4's estimate is 1.7-fold (0.23 log units) above it; low and high end bracket the measured number.
By their numbers in this assay, from the lowest: compounds 2, 3, 4 and 1 (each within the scatter of the next, the first and the last beyond it).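

In this assay, the change from sulfamoyl to methylsulfonyl gives a 1.1-fold lower number from compound 1 to compound 4 (0.06 log units; within the scatter), so the two compounds cannot be ordered against each other. Among the compounds shown here, this is the first reading at the sulfonyl sulfur, as the earlier steps concerned only a methyl or a hydrogen on an aromatic carbon, and it shows that, in this one pair, the amino group and its hydrogen-bond donor can give way to a methyl without a change beyond the scatter. No supporting measurement is available to explain this result.

The compounds shown leave open whether other groups on the sulfonyl sulfur, such as an ethyl, a dimethylamino or a cyclopropyl, would also stay within the scatter or would move the number clearly. For the compounds shown here, they also leave open whether the same exchange of amino for methyl would read the same way on the core of compound 2 or compound 3, since the only pair in hand for this change is built on the core of compound 1.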